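Nitrophenyl for Hydroxyphenyl in a Cytotoxicity Series

The compounds below may be only part of what the source reports. "The series", "measured", "known", "first", "only" and "open" are said of these compounds alone.

Compound 1 `NNC(=O)CSc1nnc(-c2ccncc2)o1` and compound 2 `O=C(CSc1nnc(-c2ccncc2)o1)N/N=C/c1ccc(O)cc1` share one core and differ at one end of the molecule. In a functional assay on HepG2 cells (Homo sapiens) for cytotoxicity, read by MTT assay, with a stated time of 48 h (a lower number here means a stronger inhibitor, a higher number a weaker inhibitor), compound 1 gives 3260 nM. In this assay compound 2 gives 5510 nM, the higher of the two numbers, yet its gap to compound 1 lies within the scatter, so the two read as alike. Compound 3 `O=C(CSc1nnc(-c2ccncc2)o1)N/N=C/c1ccccc1[N+](=O)[O-]` keeps the core of compound 2 and changes a single group: 2-nitrophenyl in place of 4-hydroxyphenyl on a carbon with a double bond to nitrogen. Among the measured compounds shown here, no pair of measured compounds shows what such a swap does, so any expectation for compound 3 rests on compound 2 alone. The expected step in this assay is a 1.1-fold lower number from compound 2 to compound 3 (0.04 log units; within the scatter), meaning no change beyond the scatter in either direction. On that basis compound 3 is estimated to give 5000 nM in this assay, with a range from 1500 nM to 16000 nM.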

Compound 3, half-maximal inhibitory concentration: 24700 nM
Compound 3: middle estimate off by 4.9-fold (0.69 log units), on the low side; measured number above the stated range.
By their numbers in this assay, from the lowest: compounds 1 and 2 (each within the scatter of the next); then compound 3.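

Among the compounds shown here, the carbon with a double bond to nitrogen is a place where the attached group can change the result, which no earlier step could show. In this assay, 2-nitrophenyl in place of 4-hydroxyphenyl gives a 4.5-fold higher number from compound 2 to compound 3 (0.65 log units; beyond the scatter), so this change makes the compound a weaker inhibitor of cell growth by a modest but real margin. No measurement here explains why the number rises.

This single swap changes both the group on the ring and its numbered place, so the compounds shown leave open which of the two matters. They also leave open how this carbon would respond to an unsubstituted phenyl or to a phenyl carrying an amine or a carboxylic acid.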